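Swapping 1-(methoxycarbonyl)ethyl for difluoro(methoxycarbonyl)methyl

This account rests on a few compounds, and the source may have more. Where it says the series, first, only, none or still open, it means among the compounds named here.

Of the compounds shown here, two sharing one core have been measured so far. In a functional assay on K562 cells (Homo sapiens) for cytotoxicity, read by trypan blue exclusion, with a stated time of 96 h (on this read-out higher numbers stand for weaker inhibition and lower numbers for stronger inhibition), compound 1 (`COC(=O)CNc1cc(CS(=O)(=O)/C=C/c2c(OC)cc(OC)cc2OC)ccc1OC`) gives 100 nM, and compound 2 (`COC(=O)[C@H](C)Nc1cc(CS(=O)(=O)/C=C/c2c(OC)cc(OC)cc2OC)ccc1OC`) gives 200 nM. Within the data shown here, compound 2 therefore holds the higher of only two numbers, although the pair lies within the scatter of repeated measurements. The next compound, compound 3 (`COC(=O)C(F)(F)Nc1cc(CS(=O)(=O)/C=C/c2c(OC)cc(OC)cc2OC)ccc1OC`), carries difluoro(methoxycarbonyl)methyl in place of 1-(methoxycarbonyl)ethyl on a nitrogen on an aromatic ring. Among the measured compounds shown here, the only measured step with a bearing on this change is a 2.0-fold higher number from compound 1 to compound 2 (0.30 log units; within the scatter), where methyl replaces hydrogen on a saturated chain carbon bound to a carbonyl carbon and a nitrogen on an aromatic ring. For the measured compounds named here, no fluorinated compound has yet been measured, so this step offers only indirect guidance. With so little evidence, no shift beyond the scatter is expected in this assay, though the uncertainty is wide. The expected change is a 1.3-fold lower number from compound 2 to compound 3 (0.12 log units; within the scatter). For compound 3, the estimated value is 150 nM, within an expected range from 50 nM to 500 nM.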

Compound 3, half-maximal inhibitory concentration: 250 nM
Compound 3: the middle estimate sits 1.7-fold (0.22 log units) below what was measured; the range from low to high includes it.
By their numbers in this assay, from the lowest: compounds 1, 2 and 3 (each within the scatter of the next, the first and the last beyond it).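

In this assay, difluoro(methoxycarbonyl)methyl in place of 1-(methoxycarbonyl)ethyl on the nitrogen gives a 1.3-fold higher number from compound 2 to compound 3 (0.10 log units; within the scatter), so this exchange does not separate the two groups on this read-out. Set against the unsubstituted (methoxycarbonyl)methyl of compound 1, however, the same difluoro group gives a 2.5-fold higher number from compound 1 to compound 3 (0.40 log units; beyond the scatter), and this is the first step in the series to pass beyond the scatter, showing that a change on this chain carbon can register in the assay, if only modestly, whereas the methyl step alone stayed within it. Nothing measured here accounts for either step.

All three compounds carry the methyl ester, so the compounds shown leave open how a carboxylic acid or a primary amide in its place would read, and thus how far the ester itself matters at this position. They also leave open whether a single fluorine, or two methyl groups, on the same chain carbon would fall with compound 1, with compound 3 or somewhere else on this read-out.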